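Chloro for methyl on the thiocarbamate aryl ring

This account rests on a few compounds, and the source may have more. Where it says the series, first, only, none or still open, it means among the compounds named here.

Of the compounds shown here, two carry numbers so far. Compound 1 `S=C(Nc1ccc(Cl)cc1)OCCc1ccccn1` gives 52000 nM in an ADME assay on MT4 cells (Homo sapiens) for cytotoxicity, read by MTT assay; on this read-out lower numbers stand for higher toxicity in this test and higher numbers for lower toxicity in this test. Compound 2 `Cc1ccc(NC(=S)OCCc2ccccc2)cc1` reaches only a limit of the assay in this assay, reported as > 100000 nM; this is the upper limit described by the limit of > 100000 nM in this assay, at which 1 of the 2 values shown sits, at which one of the two values shown sits, so compound 2 stands at the least toxic end of what has been recorded and carries no exact number.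

Compound 3 `S=C(Nc1ccc(Cl)cc1)OCCc1ccccc1` is the unmeasured partner of compound 2. The change is chloro in place of methyl on an aromatic carbon, para to a large group. For the measured compounds named here, no pair of measured compounds differs by this change alone, so the size of the step has to be guessed; a small shift in either direction, not beyond the scatter, is the expectation, since the limit of compound 2 leaves room for little movement upward. The expected step from compound 2 to compound 3 is an at least 1.1-fold lower number from compound 2 to compound 3 (0.07 log units; that floor lies within the scatter). For compound 3 the estimate in this assay is 85000 nM, with a range from 30000 nM to 200000 nM.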

Compound 3, half-maximal cytotoxic concentration: > 100000 nM
Compound 3: no number, only a limit; the forecaster's own chance of this, stated with the estimate: 45%; middle value at least 1.1-fold (0.07 log units) from the limit.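

With chloro on the aromatic carbon para to a large group, compound 3 stays at a limit of this assay, as compound 2 does with methyl, so the step for this change cannot be read: the limit of > 100000 nM in this assay, at which 2 of the 3 values shown sit.

For the compounds shown here, the one readable comparison holds the chloro ring constant and puts phenyl in place of pyridin-2-yl, giving an at least 1.9-fold higher number from compound 1 to compound 3 (0.28 log units; that floor lies within the scatter). As far as these compounds go, that floor does not separate the two compounds beyond the scatter, and the true gap remains unknown since compound 3 carries only a limit.

Neither the size nor the direction of any effect of chloro against methyl at this position can be taken from compound 2 and compound 3, since both rest on limits. Open too, from the compounds shown here alone, is how this assay responds to an amine or a carboxylic acid on the aryl ring, or to a longer chain on the oxygen, and whether such changes bring phenyl compounds to a measurable number.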